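The source may report more compounds than this note shows. Statements on the series, on what has been measured and on what is new or still open speak of the compounds shown alone.

Compound 1: `O=C1c2ccccc2C(=O)N1CNc1ccc(Cl)cc1` — in an assay on isolated protein for inhibition of ribosomal protein S6 kinase alpha-2 (Homo sapiens), read by fluorescence, with a stated time of 20 min (on this read-out higher numbers stand for weaker inhibition and lower numbers for stronger inhibition), compound 1 gives "not determined" (no result reported).
Compound 2: `CCc1ccc(NCN2C(=O)c3ccccc3C2=O)cc1` — in this assay compound 2 gives 4310 nM.
Compound 3: `CCOc1ccc(NCN2C(=O)c3ccccc3C2=O)cc1` — in this assay compound 3 gives 590 nM.

Among the two numbers available, compound 3 has the lower one, and a lower number here means stronger inhibition. Going by the values given here, the only step measured so far is a 7.3-fold lower number from compound 2 to compound 3 (0.86 log units; beyond the scatter), and it concerns the group on the ring that carries the amine nitrogen, not the other ring of the shared core.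

Compound 4 `CCOc1ccc(NCN2C(=O)c3ccc([N+](=O)[O-])cc3C2=O)cc1` is the next step from compound 3. The change is nitro in place of hydrogen on an aromatic carbon. Among the compounds with values here, this is the first change made on that part of the core, so none of the measured steps bears directly on it; the step from compound 2 to compound 3 tells how the other ring responds, not this one. With no guide in the data, the most defensible expectation is a number close to that of compound 3, with no step beyond the scatter in this assay, but the range must be kept wide because nothing measured supports a tighter call. Compound 4 is therefore estimated at 550 nM, with a range from 150 nM to 2500 nM. The expected step is a 1.1-fold lower number from compound 3 to compound 4 (0.03 log units; within the scatter).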

Compound 4, half-maximal inhibitory concentration: 2830 nM
Beside the measured number, compound 4's estimate is 5.1-fold (0.71 log units) below it; measured number outside the range, above it.
By their numbers in this assay, from the lowest: compound 3; then compounds 4 and 2 (each within the scatter of the next).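

Going by these compounds alone, this is the first measured change on the ring of the shared core that is part of a fused system of two rings, and it gives a 4.8-fold higher number from compound 3 to compound 4 (0.68 log units; beyond the scatter) in this assay. A higher number here means weaker inhibition, so this part of the core is not indifferent to substitution: putting nitro in place of hydrogen on this aromatic carbon costs inhibition, whereas the earlier step, a 7.3-fold lower number from compound 2 to compound 3 (0.86 log units; beyond the scatter), was a gain made on the other ring. Nothing in the data explains why nitro has this effect on the number.

A single group on a single carbon cannot show whether the weaker inhibition belongs to nitro itself or would follow from any group placed there, and an amine, a methoxy group or a fluorine atom on the same carbon would help separate these two readings. From the compounds shown here alone, it also remains open whether the effect of nitro depends on the group on the other ring, which a compound with nitro on this carbon and ethyl in place of ethoxy would test in a single step.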